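Methoxy for methyl on the aryl group of compound 1

The source may report more compounds than this note shows. Statements on the series, on what has been measured and on what is new or still open speak of the compounds shown alone.

Measured so far:
compound 1 `Cc1ccccc1-c1cn(C)c(=O)c2[nH]c(C(=O)NCc3ccc(C(=O)Nc4ccccc4N)cc3)cc12` gives 310 nM in a functional assay on MV4-11 cells (Homo sapiens) for antiproliferative activity, read by CCK-8 assay, with a stated time of 72 h; a lower number here means a stronger inhibitor, a higher number a weaker inhibitor
compound 2 `CC(C)Oc1ccc(C(C)(C)O)cc1-c1cn(C)c(=O)c2[nH]c(C(=O)NCc3ccc(C(=O)Nc4ccccc4N)cc3)cc12` gives 40 nM in this assay

Of the two measured compounds, compound 1 holds the higher number; compound 2 sits at a lower value, and the gap between them lies beyond the scatter. Compound 3 `COc1ccccc1-c1cn(C)c(=O)c2[nH]c(C(=O)NCc3ccc(C(=O)Nc4ccccc4N)cc3)cc12` has not yet been measured. It differs from compound 1 in one place: methoxy in place of methyl on an aromatic carbon, on an aromatic carbon of a six-membered aromatic ring of carbon only, ortho to a large group. Going by the values given here, no measured pair shows this exact change, so the step can only be judged from the two values at hand. For compound 3 the expected step is a 1.6-fold lower number from compound 1 to compound 3 (0.19 log units; within the scatter). Compound 3 is therefore estimated at 200 nM, within a range from 70 nM to 600 nM.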

Compound 3, half-maximal inhibitory concentration: 200 nM
Estimate against measurement, compound 3: no gap at the digits printed; the range from low to high includes it.
By their numbers in this assay, from the lowest: compound 2; then compounds 3 and 1 (each within the scatter of the next).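

Swapping 2-methylphenyl for 2-methoxyphenyl gives the first one-place comparison at this position: in this assay, the change is a 1.6-fold lower number from compound 1 to compound 3 (0.19 log units; within the scatter). Methoxy brings an oxygen and a hydrogen-bond acceptor to this aromatic carbon, yet this step alone does not separate the two compounds in this antiproliferative read-out. Nothing shown gives a measured reason for this result.

Going by these compounds alone, compound 2 differs from compounds 1 and 3 in more than one place, so no step to it can be read, and the source of its separate value remains unassigned. Also open, going by these compounds, is how an amine, a chlorine atom or a longer ethoxy chain would read at this same place on an otherwise unchanged compound 1.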